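Piperazine substituent swap on the shared core

The compounds below may be only part of what the source reports. "The series", "measured", "known", "first", "only" and "open" are said of these compounds alone.

Working notes. Compound 1 `CC(C)Oc1nc(N)nc2ncc(-c3ccc(C#N)cc3)nc12`, compound 3 `CCOc1nc(N)nc2ncc(-c3ccc(C(F)(F)F)cc3)nc12` and compound 2 `COc1ccc(-c2cnc3nc(N)nc(N4CCN(c5ccc(C)cc5)CC4)c3n2)cc1OC` share one core. In a functional assay on cells (T-cell, Homo sapiens) for inhibition (on this read-out lower numbers stand for stronger inhibition and higher numbers for weaker inhibition), compound 2 gives 300 nM. Compound 3 gives 10000 nM in this assay. Compound 1 in this assay reaches only the assay limit, > 10000 nM, a limit and not a number; (the limit of > 10000 nM in this assay, at which 1 of the 3 values shown sits). Compound 2 therefore holds the lowest of the two numbers; its nearest neighbour, compound 3, sits far beyond the scatter above it, and the remaining value is a limit. Among the measured compounds shown here, no pair of measured compounds differs in one place, so no measured step is available for this series.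

Compound 4 `COc1ccc(-c2cnc3nc(N)nc(N4CCN(C(=O)Nc5ccc(F)cc5)CC4)c3n2)cc1OC` differs from compound 2 as follows: (4-fluorophenyl)carbamoyl in place of 4-methylphenyl on an amine nitrogen in a ring. The rest of the structure is unchanged. Without a measured step of this type, the change is expected to move the number moderately upward, somewhat beyond the scatter. The expected step of a 2.3-fold higher number from compound 2 to compound 4 (0.37 log units; beyond the scatter) is a moderate rise. Compound 4 is estimated at 700 nM in this assay, with a range from 150 nM to 3500 nM.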

Compound 4, half-maximal inhibitory concentration: 7 nM
For compound 4 the middle estimate is 100-fold (2.00 log units) above the measured one; the whole stated range lies above it.
By their numbers in this assay, from the lowest: compound 4; then compound 2; then compound 3.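

In this assay, the substituent on an amine nitrogen in a ring proves to be a position where the read-out responds strongly: (4-fluorophenyl)carbamoyl in place of 4-methylphenyl gives a 43-fold lower number from compound 2 to compound 4 (1.63 log units; beyond the scatter). Among the compounds shown here, as the only measured step, it shows that a six-membered aromatic ring of carbon only is present on both sides of the change, while the entering group also brings a carbonyl, the amide hydrogen and fluorine. Nothing measured here accounts for the size of this step.

The carbonyl with its amide hydrogen and the fluorine enter together, so their separate shares in the step remain unresolved. Also open, as far as these compounds go, is how a simple acetyl, a phenylcarbamoyl without fluorine or a cyclohexylcarbamoyl would behave at this amine nitrogen.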